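A few compounds are considered here, and "the series" means these few. Any claim that something is new, unique, unknown or untested is made for them only; others in the source may bear on it.

Of the compounds shown here, two that share a core have been tested in a functional assay on MOLT-3 cells (Homo sapiens) for antiproliferative activity; on this read-out lower numbers stand for stronger inhibition and higher numbers for weaker inhibition. Compound 1 (`Cc1c(F)c(=O)[nH]c(=O)n1C1O[C@H](CO)[C@@H](O)[C@H]1O`) gives > 10 ug/mL, which is a limit of the assay and not a number. Compound 2 (`O=c1cc(CO)n(C2O[C@H](CO)[C@@H](O)[C@H]2O)c(=O)[nH]1`) gives > 10 ug/mL, which is also only a limit. The record so far is the limit of > 10 ug/mL in this assay, at which 2 of the 2 values shown sit, so no measured number yet fixes where compound 2 stands. Compound 3 (`O=c1cc(CF)n(C2O[C@H](CO)[C@@H](O)[C@H]2O)c(=O)[nH]1`) differs from compound 2 in one place, with fluoro in place of hydroxy on a saturated chain carbon bound to an aromatic carbon. Going by the values given here, no measured step is available as a guide, so no change beyond the scatter is expected in this assay, and no direction is foreseen. The estimated step is a step that the limit leaves unreadable from compound 2 to compound 3. The expected value for compound 3 is 15 ug/mL, with an estimated range of 6 ug/mL to 50 ug/mL.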

Compound 3, half-maximal inhibitory concentration: > 10 ug/mL
Compound 3 was reported as a limit; the forecaster's own chance of this, stated with the estimate: 80%; the middle value does not contradict the limit.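

Compound 2 and compound 3 both stand only as limits in this assay, so no step can be read between them: the limit of > 10 ug/mL in this assay, at which 3 of the 3 values shown sit.

The compounds shown leave open whether going from hydroxymethyl to fluoromethyl changes this read-out at all, and where any of the three would fall as a measured number.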